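Replacing the dihydroindole amide of a thiocarbamate series

A few compounds are considered here, and "the series" means these few. Any claim that something is new, unique, unknown or untested is made for them only; others in the source may bear on it.

Measured compounds:
compound 1 `Nc1ccccc1NC(=O)c1ccc(CSC(=S)N2CCN(Cc3ccccn3)CC2)cc1` gives 14.2%
compound 2 `Nc1ccccc1NC(=O)c1ccc(CSC(=S)N2CCc3ccccc32)cc1` gives 38%

Going by the values given here, in a functional assay on HeLa cells (Homo sapiens) for antiproliferative activity, read by CCK-8 assay, with a stated time of 72 h, tested at 2 uM (a higher number here means a stronger effect of the compound at the concentration tested, a lower number a weaker effect), compound 2 stands highest of the two numbers measured so far; the nearest compound is compound 1, whose value is lower by a gap that lies beyond the usual scatter of this kind of measurement. Compound 3 `CN(C(=S)SCc1ccc(C(=O)Nc2ccccc2N)cc1)c1cccnc1` has not yet been measured. Its structure departs from compound 2 at a single place: methyl(pyridin-3-yl)amino in place of 2,3-dihydro-1H-indol-1-yl on a thiocarbonyl carbon. Both compounds share the core of compound 2, and the change touches only the amine attached to the thiocarbonyl carbon.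

Among the compounds with values here, no step between measured compounds of this study is available to guide the size of the change, and the two numbers in hand come from compounds that differ in more than one place. Within the data shown here, the only hint is that compound 1, which also carries a pyridine within its amine part, gives 14.2% in this assay, a weaker effect than compound 2. On that thin basis, compound 3 is expected to give a modest downward step, a number 14 percentage points lower from compound 2 to compound 3 (beyond the scatter), one that may or may not clear the scatter. Compound 3 is therefore estimated at 24% in this assay, with a range from 8% to 44%.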

Compound 3, a percentage reported as inhibition, at one concentration (the size of the read-out at that concentration, not a potency): 16%
Beside the measured number, compound 3's estimate is 8 percentage points above it; the range from low to high includes it.
By their numbers in this assay, from the lowest: compounds 1 and 3 (each within the scatter of the next); then compound 2.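

In this assay the position on the thiocarbonyl carbon responds clearly to the amine it carries: the first single-place change available in this series gives a number 22 percentage points lower from compound 2 to compound 3 (beyond the scatter) and so shows that this part of the molecule is not a silent one. The change is not a simple one, since 2,3-dihydro-1H-indol-1-yl, with 9 heavy atoms, a five-membered non-aromatic ring and a six-membered aromatic ring of carbon only, gives way to methyl(pyridin-3-yl)amino, with 8 heavy atoms, a single six-membered aromatic ring with 1 hetero atom and 1 hydrogen-bond acceptor where the group that leaves has 0. Nothing available bears on why the number falls, so the step cannot be assigned to any one of these differences.

The compounds shown leave open whether the fall follows the ring nitrogen of the pyridine or the loss of the five-membered ring. As far as these compounds go, a methyl(phenyl)amino group or a morpholin-4-yl group on the same thiocarbonyl carbon would speak to this, and how either reads in this assay remains unknown here.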